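From Tellurium to Selenium: One Atom Changes

The compounds below may be only part of what the source reports. "The series", "measured", "known", "first", "only" and "open" are said of these compounds alone.

In a physicochemical assay for lipophilicity, read by HPLC, measured as octanol-water partition (on this read-out higher numbers stand for higher lipophilicity and lower numbers for lower lipophilicity), compound 2 (`COc1ccc(N(CC(=O)NCCC[Te]c2ccccc2)C(=O)CNC(=O)OC(C)(C)C)cc1`) gives 4.2, level with compound 1 (`COc1ccc(N(CC(=O)NCCCSc2ccccc2)C(=O)CCSC2=C(C)C(=O)c3ccccc3C2=O)cc1`) at 4.2. These two share the top of the small set, while compound 3 (`O=C(COC(=O)/C=C/c1ccccc1)NCCC[Te]c1ccccc1`) lies clearly lower at 3.01.

Compound 4 (`COc1ccc(N(CC(=O)NCCC[Se]c2ccccc2)C(=O)CNC(=O)OC(C)(C)C)cc1`) keeps the structure of compound 2 except for one swap: a group of 7 heavy atoms (6 carbon, 1 selenium; one six-membered aromatic ring of carbon only) in place of a group of 7 heavy atoms (6 carbon, 1 tellurium; one six-membered aromatic ring of carbon only), on a saturated chain carbon, three bonds along the chain from an amide-type nitrogen. The swap lies on a saturated chain carbon, three bonds along the chain from an amide-type nitrogen. The two groups match in everything counted except the one heavy atom that differs.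

Going by the values given here, no measured pair isolates this exchange, so the data offer no direct guide to its size or direction. A small change is the cautious expectation, and the direction, slightly downward in this assay, is tentative. The expected shift is a number 0.20 log units lower from compound 2 to compound 4 (within the scatter), which would stay within the usual scatter.

For compound 4 the estimated value is 4, with an expected range from 3.6 to 4.4.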

Compound 4, partition coefficient: 3.3
For compound 4 the middle estimate is 0.70 log units above the measured one, outside the stated range (below it).
By their numbers in this assay, from the lowest: compounds 3 and 4 (each within the scatter of the next); then compounds 1 and 2 (each within the scatter of the next).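

Going by these compounds alone, this is the first change in the set made in a single place: on a saturated chain carbon, three bonds along the chain from an amide-type nitrogen, the selenium group in place of the tellurium group gives a number 0.90 log units lower from compound 2 to compound 4 (beyond the scatter) in this assay for this pair. The two groups match in everything counted except that one heavy atom. The step lies beyond the usual scatter of repeated measurements. Nothing shown accounts for the size of this step.

On these data alone, it remains open whether the same exchange would give a step of similar size on the core of compound 3, which also carries the tellurium group. As far as these compounds go, how a phenoxy group, with oxygen as the one differing heavy atom, would read at this position also remains open.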